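The compounds below may be only part of what the source reports. "The series", "measured", "known", "first", "only" and "open" are said of these compounds alone.

Measured so far:
compound 1 `Cc1nc2c3ccccc3ccc2c2nc3c(ccc4ccccc43)c(-c3cccnc3)c12`: 156 ug/mL
compound 2 `Cc1nc2c3ccccc3ccc2c2nc3c(ccc4ccccc43)c(-c3ccccc3Cl)c12`: 170 ug/mL

Both values come from a functional assay, with a stated time of 90 s; a higher number here means a weaker inhibitor, a lower number a stronger inhibitor. Going by the values given here, compound 2 holds the higher of the two numbers, and the only measured step, a 1.1-fold higher number from compound 1 to compound 2 (0.04 log units; within the scatter), stays within the scatter, so the two compounds cannot be ordered.

Compound 3 `Cc1nc2c3ccccc3ccc2c2nc3c(ccc4ccccc43)c(-c3ccccc3S)c12` is not yet measured. Its change from compound 2: sulfanyl in place of chloro on an aromatic carbon. Among the compounds with values here, no measured step covers this exchange; the one step in hand, a 1.1-fold higher number from compound 1 to compound 2 (0.04 log units; within the scatter), concerns a different change and was itself within the scatter. A step of a 1.1-fold lower number from compound 2 to compound 3 (0.03 log units; within the scatter) is therefore expected, that is none beyond the scatter. Compound 3 is estimated at 160 ug/mL, within 80 ug/mL to 320 ug/mL.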

Compound 3, half-maximal inhibitory concentration: 158 ug/mL
Beside the measured number, compound 3's estimate is 1.0-fold (0.01 log units) above it, and the stated range covers the measured number.
By their numbers in this assay, from the lowest: compounds 1, 3 and 2 (each within the scatter of the next).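

In this assay, the exchange of 2-chlorophenyl for 2-sulfanylphenyl gives a 1.1-fold lower number from compound 2 to compound 3 (0.03 log units; within the scatter) and the exchange of pyridin-3-yl for 2-sulfanylphenyl gives a 1.0-fold higher number from compound 1 to compound 3 (0.01 log units; within the scatter) in this series. This position has now carried three groups with no step beyond the scatter, and the sulfanyl group adds a hydrogen-bond donor and a hydrogen-bond acceptor to the 2-substituted phenyl without a readable shift. No measurement here bears on why the numbers stay together.

From the compounds shown here alone, whether an amine, a carboxylic acid or a longer chain at this position would give a step beyond the scatter remains open. Changes elsewhere on the shared core also remain open.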